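Adding a Second Methoxy Group to a Flat Series

A few compounds are considered here, and "the series" means these few. Any claim that something is new, unique, unknown or untested is made for them only; others in the source may bear on it.

Three compounds built on one shared core were tested in an ADME assay on K562 cells (Homo sapiens) for cytotoxicity, with a stated time of 72 h; a lower number here means a stronger inhibitor, a higher number a weaker inhibitor. Compound 1 `COc1cccc(CNc2ncnc3c2ncn3C2CCCO2)c1` carries a 3-methoxyphenyl group, and in this assay compound 1 gives > 100000 nM, which is a limit of the assay rather than a number. Compound 2 `COc1ccc(CNc2ncnc3c2ncn3C2CCCO2)cc1` differs from compound 1 in its core: 3-methoxyphenyl in place of 4-methoxyphenyl on a saturated chain carbon bound to a nitrogen on an aromatic ring. In this assay compound 2 gives > 100000 nM, again only a limit. The step that the two limits leave unreadable from compound 1 to compound 2 therefore cannot be sized. Compound 3 `COc1ccc(CNc2ncnc3c2ncn3C2CCCO2)c(OC)c1` differs from compound 2 by methoxy in place of hydrogen on an aromatic carbon. In this assay compound 3 gives > 100000 nM, once more a limit, so a step that the two limits leave unreadable from compound 2 to compound 3 is equally unreadable. All three values rest at the limit of > 100000 nM in this assay, at which 3 of the 3 values shown sit.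

Compound 4 `COc1ccc(OC)c(CNc2ncnc3c2ncn3C2CCCO2)c1` has not yet been measured. It differs from compound 1 by methoxy in place of hydrogen on an aromatic carbon. Among the compounds with values here, this is the same kind of change as the one from compound 2 to compound 3, though not the same: there the entering methoxy sits meta to a methoxy group, here it sits para to a methoxy group. Because the limit of > 100000 nM in this assay, at which 3 of the 3 values shown sit, holds every measured value, the step that the limit leaves unreadable from compound 1 to compound 4 is expected to stay unreadable as well. Compound 4 is expected to give 150000 nM in this assay, most probably reported only as a limit.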

Compound 4, half-maximal inhibitory concentration: > 50000 nM
Compound 4 was reported as a limit; the forecaster's own chance of this, stated with the estimate: 85%; the middle value does not contradict the limit.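

In this assay compound 4 gives > 50000 nM, which is a limit and not a number. Compound 1 also has only a limit, so the step from compound 1 to compound 4 cannot be read. The compounds shown leave open how compounds 1, 2, 3 and 4 rank, and whether a methoxy group changes their cytotoxicity at all.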